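Phenyl in Place of Chloro: An Expected Outcome

A few compounds are considered here, and "the series" means these few. Any claim that something is new, unique, unknown or untested is made for them only; others in the source may bear on it.

Compound 1 `NN(c1ccccc1)c1nnc(-c2ccccc2Cl)s1` was examined in a functional assay on the whole organism with Mus musculus as the target, in the maximal electroshock model, with a stated time of 1 h; a higher number here means that more compound is needed for the effect, a lower number that less compound is needed. For compound 1 the result is only a limit, > 100 mg/kg. This is the limit of > 100 mg/kg in this assay, at which 1 of the 2 values shown sits. Compound 2 `NN(Cc1ccccc1)c1nnc(-c2ccccc2Cl)s1` gives 186 mg/kg in this assay. The step that the limit leaves unreadable from compound 1 to compound 2 therefore cannot be read as a number, since it begins at a limit. Compound 3 `NN(c1ccccc1)c1nnc(-c2ccccc2-c2ccccc2)s1` carries the change (phenyl in place of chloro on an aromatic carbon). Among the compounds with values here, no measured step concerns a change of this kind, and the single measured step available starts from a limit, so nothing measured indicates the direction or size of the effect in this assay. Within the data shown here, with no measured step to lean on, compound 3 is expected at 150 mg/kg, between 60 mg/kg and 400 mg/kg, which would mean an expected step that the limit leaves unreadable from compound 1 to compound 3. Compound 3 may well again yield only a limit in this assay.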

Compound 3, dose for half-maximal effect: > 100 mg/kg
Compound 3 was reported as a limit; the forecaster's own chance of this, stated with the estimate: 50%; the middle value is on the limit's open side.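

In this assay, within the data shown here, compound 1 and compound 3 each give only a limit, so no step between them can be read. Whether phenyl in place of chloro on an aromatic carbon changes the dose needed, and in which direction, stays open, with both compounds at the same limit: the limit of > 100 mg/kg in this assay, at which 2 of the 3 values shown sit.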